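Replacing the ring on the chain carbon of compound 3

The source may report more compounds than this note shows. Statements on the series, on what has been measured and on what is new or still open speak of the compounds shown alone.

Going by the values given here, in an ADME assay on microsomes from liver (Homo sapiens) for metabolic stability (on this read-out higher numbers stand for a longer-lived compound and lower numbers for a shorter-lived compound), compound 3 `CC(C)C(c1ccc(-c2ccc3cccc(F)c3c2)[nH]c1=O)N1CCNC1=O` gives 1.03 h, the higher of the two exact numbers so far. The other comes from compound 1 `CC(C)C(c1ccc(-c2ccc3cccc(F)c3c2)[nH]c1=O)N1CCCCS1(=O)=O`, which gives 0.373 h. Compound 2 `CC(C)C(Nc1nnc[nH]1)c1ccc(-c2ccc3cccc(F)c3c2)[nH]c1=O` reads > 3 h, which is a limit of the assay and not a number.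

Compound 4 `CC(C)C(/C=C1\CCNC1=O)c1ccc(-c2ccc3cccc(F)c3c2)[nH]c1=O` differs from compound 3 in one group: a group of 7 heavy atoms (5 carbon, 1 nitrogen, 1 oxygen; one five-membered non-aromatic ring with 1 hetero atom) in place of a group of 6 heavy atoms (3 carbon, 2 nitrogen, 1 oxygen; one five-membered non-aromatic ring with 2 hetero atoms), on a saturated chain carbon bound to an aromatic carbon and a saturated chain carbon. The new group still holds a five-membered non-aromatic ring, and it has the same 1 hydrogen-bond donor and 1 hydrogen-bond acceptor.

Two measured exchanges at this same place bear on the change: a 2.8-fold higher number from compound 1 to compound 3 (0.44 log units; beyond the scatter) and an at least 2.9-fold lower number from compound 2 to compound 3 (0.46 log units; beyond the scatter). Both lie beyond the scatter, so a new group here can shift the half-life. Neither exchange, however, tests a group of this kind, and so they give no direction. The expected result is no change beyond the scatter, with an estimated 1.1-fold lower number from compound 3 to compound 4 (0.06 log units; within the scatter). For compound 4 the estimated half-life in this assay is 0.9 h, with an expected range from 0.35 h to 2.3 h.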

Compound 4, half-life: 0.713 h
For compound 4 the middle estimate is 1.3-fold (0.10 log units) above the measured one; low and high end bracket the measured number.
By their numbers in this assay, from the lowest: compounds 1, 4 and 3 (each within the scatter of the next, the first and the last beyond it). At a limit, above all of these: compound 2.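

In this assay, the exchange of 2-oxoimidazolidin-1-yl for the new five-membered ring group reads a 1.4-fold lower number from compound 3 to compound 4 (0.16 log units; within the scatter), so this change of ring atoms and link gives no shift that can be told from the scatter. The exchange from the six-membered ring group reads a 1.9-fold higher number from compound 1 to compound 4 (0.28 log units; within the scatter), which leaves compound 4 within the scatter of both compound 1 and compound 3, even though those two lie beyond it from each other. The exchange from the aromatic ring group reads an at least 4.2-fold lower number from compound 2 to compound 4 (0.62 log units; beyond the scatter), and it rests on a limit, not a number: the limit of > 3 h in this assay, at which 1 of the 4 values shown sits.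

The compounds shown do not separate the effect of the triazole ring in compound 2 from that of the nitrogen joining it to the chain carbon. A simple amine or a carboxylic acid on that same carbon would show whether a ring is needed there at all.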